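The compounds below may be only part of what the source reports. "The series", "measured", "known", "first", "only" and "open" are said of these compounds alone.

Measured so far:
Compound 1, `O=C(CCl)Nc1ccc(SCC(=O)Nc2cccc(Cl)c2)cc1`, in a functional assay on HeLa cells (Homo sapiens) for antiproliferative activity, read by MTT assay, with a stated time of 48 h (a higher number here means a weaker inhibitor, a lower number a stronger inhibitor), gives > 80000 nM, a limit of the assay.
Compound 2, `C=CC(=O)Nc1ccc(SCC(=O)Nc2cc(Cl)ccn2)cc1`, in this assay gives 25200 nM.
Compound 3, `C=CC(=O)Nc1ccc(SCC(=O)Nc2ccccn2)cc1`, in this assay gives > 80000 nM, again a limit.

Compound 3 therefore sits at the limit of > 80000 nM in this assay, at which 2 of the 3 values shown sit, so only a bound is known for it. Only compound 2 gives a real number. Within the data shown here, the single measured step touching compound 3, an at least 3.1-fold higher number from compound 2 to compound 3 (0.50 log units; beyond the scatter), shows that removing the chloro weakened inhibition. Compound 4, `C=CC(=O)Nc1ccc(SCC(=O)Nc2cccc(Cl)c2)cc1`, differs from compound 3 by 3-chlorophenyl in place of pyridin-2-yl on an amide-type nitrogen. This restores a chloro, though on a different ring. Compound 1 carries the same 3-chlorophenyl amide and is itself a limit. Among the measured compounds shown here, no measured step covers this ring exchange. Compound 4 is thus expected to stay weak, with an at least 1.4-fold lower number from compound 3 to compound 4 (0.16 log units; that floor lies within the scatter) at most a modest gain. The estimate for compound 4 is 55000 nM, between 15000 nM and 120000 nM.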

Compound 4, half-maximal inhibitory concentration: > 80000 nM
Compound 4: a limit, no number; the forecaster's own chance of this, stated with the estimate: 55%; middle value at least 1.4-fold (0.16 log units) from the limit.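

Placing 3-chlorophenyl in place of 4-chloropyridin-2-yl on the amide-type nitrogen gives an at least 3.1-fold higher number from compound 2 to compound 4 (0.50 log units; beyond the scatter). A chloro on the aromatic ring is therefore not enough to keep a measurable value, and among these compounds only the chloro-bearing pyridin-2-yl ring of compound 2 gives one. Compound 4 is a limit, and its steps from compound 3 and from compound 1 cannot be read: the limit of > 80000 nM in this assay, at which 3 of the 4 values shown sit.

On these data alone, it remains open whether a methoxy group or an amine in place of the chloro on the pyridin-2-yl ring would preserve the activity of compound 2.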